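Trimming the diol of compound 2: expected lipophilicity

A few compounds are considered here, and "the series" means these few. Any claim that something is new, unique, unknown or untested is made for them only; others in the source may bear on it.

Within the data shown here, compound 2 `Cc1cc(Cl)ccc1OCC(O)CO` stands lowest of the two numbers so far in a physicochemical assay for lipophilicity, measured as octanol-water partition (on this read-out higher numbers stand for higher lipophilicity and lower numbers for lower lipophilicity), where compound 2 gives 2.08 as its partition coefficient. Its nearest neighbour is compound 1 `CC(O)COc1ccc(Cl)cc1Cl`, which in this assay gives 2.75, a gap beyond the usual scatter. Compound 3 `Cc1cc(Cl)ccc1OCC(C)O` is not yet measured; the difference from compound 2 is hydrogen in place of hydroxy on a saturated chain carbon, two bonds along the chain from an oxygen on a saturated carbon on the chain. Among the measured compounds shown here, no step between measured compounds is on hand for guidance. The expected step is a number 0.77 log units higher from compound 2 to compound 3 (beyond the scatter), upward and beyond the scatter. Compound 3 is estimated at 2.85, with a range from 2.5 to 3.2 in this assay.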

Compound 3, partition coefficient: 2.84
Compound 3: middle estimate off by 0.01 log units, on the high side, and the stated range covers the measured number.
By their numbers in this assay, from the lowest: compound 2; then compounds 1 and 3 (each within the scatter of the next).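

In this assay, among these compounds, hydrogen in place of hydroxy on this saturated chain carbon gives the first measured step at this position, a number 0.76 log units higher from compound 2 to compound 3 (beyond the scatter), so the change moves the number. By contrast, methyl in place of chloro on an aromatic carbon gives a number 0.09 log units higher from compound 1 to compound 3 (within the scatter), leaving no separation at that site. Nothing on hand gives a reason for either step. Going by these compounds, it remains open whether an amine or a carboxylic acid on the same chain carbon would shift the number as far, and whether the hydroxy step holds with chloro on the aromatic carbon.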